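From Dimethylpyrazole to Tetrazole: an Expected Loss

A few compounds are considered here, and "the series" means these few. Any claim that something is new, unique, unknown or untested is made for them only; others in the source may bear on it.

Of the compounds shown here, two have been measured in an assay on cells for inhibition of MAP kinase-interacting serine/threonine-protein kinase 1 (Homo sapiens), read by mobility shift assay, with stated times of 10 min and 60 min, in the presence of a further agent that is not named here; on this read-out lower numbers stand for stronger inhibition and higher numbers for weaker inhibition. Compound 1 `Cc1n[nH]c(C)c1-c1cncc(-c2ccc(C(N)=O)c(OC(C)C)c2)c1` gives 33 nM, the lower of the two numbers, while compound 2 `NC(=O)c1ccc(-c2cccnc2)cc1OC1CCCCC1` gives 1500 nM; that gap lies beyond the usual scatter. Compound 3 `CC(C)Oc1cc(-c2cncc(-c3nn[nH]n3)c2)ccc1C(N)=O` has not yet been measured. It differs from compound 1 in one place: 2H-tetrazol-5-yl in place of 3,5-dimethyl-1H-pyrazol-4-yl on an aromatic carbon. For the measured compounds named here, no measured pair shows this particular exchange, so its effect can only be estimated. The expectation is a weakening step a 6.1-fold higher number from compound 1 to compound 3 (0.78 log units; beyond the scatter), somewhat beyond the scatter. Compound 3 is therefore estimated at 200 nM, with a likely range from 50 nM to 1500 nM.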

Compound 3, half-maximal inhibitory concentration: 310 nM
Compound 3: the middle estimate sits 1.6-fold (0.19 log units) below what was measured; the measured number falls inside the stated range.
By their numbers in this assay, from the lowest: compound 1; then compound 3; then compound 2.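

In this assay this aromatic carbon proves sensitive to the group it carries: there is a 9.4-fold higher number from compound 1 to compound 3 (0.97 log units; beyond the scatter) when 2H-tetrazol-5-yl takes the place of 3,5-dimethyl-1H-pyrazol-4-yl. Both groups are five-membered aromatic rings with one hydrogen-bond donor, so sharing those two features does not preserve the number of compound 1. Nothing available explains this step.

The compounds shown do not separate the loss of the two methyl groups from the gain of ring nitrogens. Going by these compounds, how a pyrazole without methyl groups, or a carboxylic acid at this place, would read remains open.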